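A few compounds are considered here, and "the series" means these few. Any claim that something is new, unique, unknown or untested is made for them only; others in the source may bear on it.

In a functional assay on MCF7 cells (Homo sapiens) for antiproliferative activity, read by MTT assay (a higher number here means a weaker inhibitor, a lower number a stronger inhibitor), compound 1 `COc1cc2c(Oc3ccc(NC(=O)Nc4ccccc4)cc3)ccnc2cc1OCCCCCCC(=O)NO` gives 1040 nM, compound 2 `COc1cc2c(Oc3ccc(NC(=O)Nc4ccc(C)cc4C)cc3)ccnc2cc1OCCCCCCC(=O)NO` gives 3430 nM and compound 3 `COc1cc2c(Oc3ccc(NC(=O)N/N=C/c4ccccc4F)cc3)ccnc2cc1OCCCCCCC(=O)NO` gives 1610 nM. Compound 3 cannot be told apart from compound 1 on these numbers, while compound 2 has the highest number of the three. Two steps fix that position: a 1.5-fold higher number from compound 1 to compound 3 (0.19 log units; within the scatter) and a 2.1-fold lower number from compound 2 to compound 3 (0.33 log units; beyond the scatter).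

Compound 4 `COc1cc2c(Oc3ccc(NC(=O)NNC(=O)c4cccc(C)c4)cc3)ccnc2cc1OCCCCCCC(=O)NO` keeps the shared core and differs only on the amide-type nitrogen: a group of 10 heavy atoms (8 carbon, 1 nitrogen, 1 oxygen; one six-membered aromatic ring of carbon only) in place of a group of 9 heavy atoms (7 carbon, 1 nitrogen, 1 fluorine; one six-membered aromatic ring of carbon only), on an amide-type nitrogen. Going by the values given here, the entering group is ((3-methylphenyl)carbonyl)amino, and no measured compound carries it, so the data give no direct precedent for this change.

Among the compounds with values here, the only guide is how far other replacements on this nitrogen have moved the number. The largest such change is a 3.3-fold higher number from compound 1 to compound 2 (0.52 log units; beyond the scatter), which is modest, and the replacement in compound 3 stayed within the scatter of compound 1. Neither step predicts a direction with any confidence, so this assay is expected to show a step no larger than modest, most likely none beyond the scatter. The step expected here is a 1.2-fold higher number from compound 3 to compound 4 (0.07 log units; within the scatter). For compound 4 the estimated value is 1900 nM, with an expected range of 800 nM to 4500 nM.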

Compound 4, half-maximal inhibitory concentration: 5830 nM
Estimate against measurement, compound 4: 3.1-fold (0.49 log units) below; the measured number lies above the stated range.
By their numbers in this assay, from the lowest: compounds 1 and 3 (each within the scatter of the next); then compounds 2 and 4 (each within the scatter of the next).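

Working notes on the amide-type nitrogen: in this assay, ((3-methylphenyl)carbonyl)amino shows that this position is less forgiving than compound 3 alone suggested, with a 3.6-fold higher number from compound 3 to compound 4 (0.56 log units; beyond the scatter) and a 5.6-fold higher number from compound 1 to compound 4 (0.75 log units; beyond the scatter). The new group adds a hydrogen-bond donor to what compound 3 carries there and brings the number level with the 2,4-dimethylphenyl of compound 2, as a 1.7-fold higher number from compound 2 to compound 4 (0.23 log units; within the scatter) cannot be told from scatter, so the four compounds now fall into two tiers: compounds 1 and 3 form the lower pair, and compounds 2 and 4 the higher. Going by these compounds alone, both groups in the higher tier carry methyl and neither group in the lower tier does, but with only two compounds on each side this is an observation on these four alone, and no supporting measurement is available to explain the shift.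

On these data alone, whether the step follows the methyl or the carbonyl-linked hydrazide stays open, and (phenylcarbonyl)amino without the methyl would separate the two. It is also unclear whether an amine or a carboxylic acid on the same ring would stay in the higher tier or return to the lower one.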